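The source may report more compounds than this note shows. Statements on the series, on what has been measured and on what is new or still open speak of the compounds shown alone.

The study centres on a shared core, seen in compound 1 `N#Cc1ccn2c(-c3ccccc3)c(-c3ccccc3)c(OCOCc3ccccc3)c2c1` and in compound 2 `Cc1c(-c2ccccc2)c(-c2ccccc2)n2ccc(C#N)cc12`. For the measured compounds named here, in an assay for inhibition of Polyunsaturated fatty acid lipoxygenase ALOX15 (Oryctolagus cuniculus) (on this read-out higher numbers stand for weaker inhibition and lower numbers for stronger inhibition), compound 1 gives 39000 nM, the only number reported; in this assay compound 2 gives "not determined" (no result reported). Compound 3 `N#Cc1ccn2c(-c3ccccc3)c(-c3ccccc3)c(C(O)c3ccccc3)c2c1` is the analogue still to be measured. It differs from compound 1 in one place: hydroxy(phenyl)methyl in place of (benzyloxy)methoxy on an aromatic carbon. Going by the values given here, no step between measured compounds is available, so the step of a 1.3-fold lower number from compound 1 to compound 3 (0.11 log units; within the scatter) is expected to stay within the usual scatter, with no clear direction. On that basis, compound 3 is expected to give 30000 nM in this assay, within a range of 8000 nM to 100000 nM.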

Compound 3, half-maximal inhibitory concentration: 48000 nM
The estimate for compound 3 lay 1.6-fold (0.20 log units) below the measured number; the measured number falls inside the stated range.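

In this assay, putting hydroxy(phenyl)methyl in place of (benzyloxy)methoxy on this aromatic carbon gives a 1.2-fold higher number from compound 1 to compound 3 (0.09 log units; within the scatter) and so leaves the read-out within the scatter. At this position, the exchange removes the longer chain and brings in a hydrogen-bond donor, with no clear change in the number. Nothing at hand accounts for this result.

What the compounds shown leave open is whether any group here can move the number beyond the scatter. An amine or a carboxylic acid on this carbon, or a group with no phenyl ring, such as hydroxymethyl, would test this.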